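From 2-chlorophenyl to 4-chlorophenyl on the amide

This account rests on a few compounds, and the source may have more. Where it says the series, first, only, none or still open, it means among the compounds named here.

- compound 1 (`CC(=O)SCCC(CCCCC(=O)O)SC(C)=O`) - 9.96%
- compound 2 (`CC(=O)SCCC(CCCCC(=O)Nc1ccccc1Cl)SC(C)=O`) - 16.6%

In a functional assay on NCI-H460 cells (Homo sapiens) for inhibition, read by MTT assay, with a stated time of 24 h, tested at 0.1 ug/mL (a lower number here means less inhibition of growth, a higher number more inhibition of growth at the concentration tested), compound 2 gives 16.6% and compound 1 gives 9.96% and these two numbers cannot be told apart. Compound 3 (`CC(=O)SCCC(CCCCC(=O)Nc1ccc(Cl)cc1)SC(C)=O`) has 4-chlorophenyl in place of 2-chlorophenyl on an amide-type nitrogen with the same atoms joined differently. Going by the values given here, no measured pair compares these two groups directly. Among the compounds with values here, with a number 6.6 percentage points higher from compound 1 to compound 2 (within the scatter) as the only measured step, for (2-chlorophenyl)amino in place of hydroxy on a carbonyl carbon, no step beyond the scatter and no particular direction is expected for compound 3. The estimate therefore means a number 1.6 percentage points lower from compound 2 to compound 3 (within the scatter) as the expected step. Compound 3 is expected at 15% with an estimated range from 6% to 28% in this assay once it is measured.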

Compound 3, percent growth inhibition at one concentration: 9.89%
Compound 3: the middle estimate sits 5.1 percentage points above what was measured, within the range that was stated.
By their numbers in this assay, from the lowest: compounds 3, 1 and 2 (each within the scatter of the next).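

Putting 4-chlorophenyl in place of 2-chlorophenyl on the amide-type nitrogen gives a number 6.7 percentage points lower from compound 2 to compound 3 (within the scatter) in this assay, so this first comparison of the two groups separates them by no more than the usual scatter. The step from the free acid, a number 0.1 percentage points lower from compound 1 to compound 3 (within the scatter), is also within the scatter, and so compound 1, compound 2 and compound 3 cannot be told apart here, whichever of the two chlorophenyl groups sits on the amide. Nothing available explains these numbers.

As far as these compounds go, it remains open whether a group of another kind on that nitrogen, such as plain phenyl, 4-methoxyphenyl or a short alkyl chain, would give a step beyond the scatter. Also open, from the compounds shown here alone, is whether compound 2 and compound 3 would stay together at other concentrations.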